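This account rests on a few compounds, and the source may have more. Where it says the series, first, only, none or still open, it means among the compounds named here.

In an ADME assay on TERT-RPE1 cells (Homo sapiens) for cytotoxicity, read by MTT assay, with a stated time of 72 h (a higher number here means a weaker inhibitor, a lower number a stronger inhibitor), compound 3 `COc1ccc(/C=C2\S/C(=N\c3ccc(C)c(Cl)c3)N(C)C2=O)cc1` gives 23000 nM. That is level with compound 1 `COc1ccc(/C=C2/CN(C)/C(=N/c3ccc(C(C)(C)C)cc3)S2)cc1`, which gives 23500 nM, while compound 2 `COc1ccc(/C=C2/CN(C)/C(=N/c3ccc(C)cc3)S2)cc1` gives the higher number of 65700 nM. The next compound to be measured is compound 4 `COc1ccc(/C=C2\S/C(=N\c3ccccc3)N(C)C2=O)cc1`, which keeps the core of compound 3 and carries phenyl in place of 3-chloro-4-methylphenyl on a double-bonded nitrogen.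

Within the data shown here, no measured step makes this exact change, and none removes a chlorine. Among the measured compounds shown here, only one measured step bears on it, and it comes from a different core. This is a 2.8-fold higher number from compound 1 to compound 2 (0.45 log units; beyond the scatter), where methyl replaces tert-butyl on an aromatic carbon. That step is modest, and like the change to compound 4 it strips carbon from a substituent on the aromatic ring. With this single precedent as a guide, a modest move towards a higher number, and so towards weaker inhibition, seems the likeliest outcome, although a result within the scatter would be no surprise. The expected change is a 2.0-fold higher number from compound 3 to compound 4 (0.29 log units; within the scatter). For compound 4 the estimated value is 45000 nM, with an expected range from 20000 nM to 100000 nM.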

Compound 4, half-maximal inhibitory concentration: > 100000 nM
Compound 4 gave a limit, no number; the forecaster's own chance of this, stated with the estimate: 15%; middle value at least 2.2-fold (0.34 log units) away from the limit.
By their numbers in this assay, from the lowest: compounds 3 and 1 (each within the scatter of the next); then compound 2. At a limit, above all of these: compound 4.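

In this assay, phenyl in place of 3-chloro-4-methylphenyl on a double-bonded nitrogen gives an at least 4.3-fold higher number from compound 3 to compound 4 (0.63 log units; beyond the scatter), so this position on the core of compound 3 is not indifferent to the change. Among these compounds, compound 4 gives > 100000 nM, which is a limit of the assay and not a number: the limit of > 100000 nM in this assay, at which 1 of the 4 values shown sits. The earlier compounds offered only a change on a different core, a 2.8-fold higher number from compound 1 to compound 2 (0.45 log units; beyond the scatter), and the new step shows that on this second core, too, stripping carbon from the aryl group on the double-bonded nitrogen goes with a higher number, though the full size of the new step stays unknown.

The change removes the chlorine and the methyl together, so the compounds shown do not tell which of the two accounts for the step, or whether both are needed. They also leave open how this assay would read with a longer chain, an amine or a carboxylic acid on the phenyl ring of compound 4, and whether the same replacement on the core of compound 1 would give a step of similar size.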